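This account rests on a few compounds, and the source may have more. Where it says the series, first, only, none or still open, it means among the compounds named here.

Measured so far in a functional assay on HEK293 cells for agonist activity at Bombesin receptor subtype-3 (Mus musculus), read by luminescence and calcium flux, with a stated time of 10 min; on this read-out higher numbers stand for an effect only at larger amounts of compound and lower numbers for an effect already at smaller amounts:
compound 1 `CCC(C)(C)Cc1c[nH]c(CCc2ccc(-n3ncnn3)cc2)n1` — compound 1 gives 99 nM
compound 2 `CCC(C)(C)Cc1c[nH]c(CCc2ccc(-c3csnn3)cc2)n1` — compound 2 gives 109 nM
compound 3 `CCC(C)(C)Cc1c[nH]c(CCc2ccc(-c3cccnc3)cc2)n1` — compound 3 gives 97 nM

Compound 3 holds the lowest of the three numbers, but only on paper: the steps of a 1.0-fold lower number from compound 1 to compound 3 (0.01 log units; within the scatter) and a 1.1-fold lower number from compound 2 to compound 3 (0.05 log units; within the scatter) both lie within the scatter, so the three compounds cannot be told apart on this read-out.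

Compound 4 `CCC(C)(C)Cc1c[nH]c(CCc2ccc(N3CCCCC3)cc2)n1` has not been measured. It differs from compound 3 in one place: piperidin-1-yl in place of pyridin-3-yl on an aromatic carbon. The measured steps that touch the same position are a 1.1-fold higher number from compound 1 to compound 2 (0.04 log units; within the scatter), a 1.0-fold lower number from compound 1 to compound 3 (0.01 log units; within the scatter) and a 1.1-fold lower number from compound 2 to compound 3 (0.05 log units; within the scatter). Each of them swaps one aromatic group for another at this position, and each stays within the scatter. None of them exchanges an aromatic ring for a non-aromatic ring, so they speak to the step from compound 3 to compound 4 only by analogy.

Given that every exchange at this position has so far left this assay unchanged beyond the scatter, the expected step of a 1.1-fold higher number from compound 3 to compound 4 (0.05 log units; within the scatter) is taken to be small, in no particular direction. Compound 4 is therefore estimated at 110 nM, with a range from 40 nM to 320 nM to allow for the untested change in ring character.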

Compound 4, half-maximal effective concentration: 133 nM
Compound 4: the middle estimate sits 1.2-fold (0.08 log units) below what was measured, within the range that was stated.
By their numbers in this assay, from the lowest: compounds 3, 1, 2 and 4 (each within the scatter of the next).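

Piperidin-1-yl is the first non-aromatic ring shown on this aromatic carbon, and in this assay its exchange for pyridin-3-yl gives a 1.4-fold higher number from compound 3 to compound 4 (0.14 log units; within the scatter), a step within the scatter. The comparisons with the other two aromatic groups, a 1.2-fold higher number from compound 2 to compound 4 (0.09 log units; within the scatter) and a 1.3-fold higher number from compound 1 to compound 4 (0.13 log units; within the scatter), also stay within the scatter, so among these four compounds an aromatic ring at this place is not needed to keep the number where it stands, and a six-membered non-aromatic ring cannot be told apart from the aromatic groups on this read-out. Nothing available bears on why this position tolerates the change.

Every group shown here is a ring, so it remains open whether a carboxylic acid, a primary amine, a longer alkyl chain or a plain hydrogen at this place would also stay within the scatter or would finally move the number. The rest of the structure is the same in all four compounds, which leaves open whether this position would remain as tolerant with a different chain on the shared core.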